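Fluoro for chloro on the fused ring: compound 4

The compounds below may be only part of what the source reports. "The series", "measured", "known", "first", "only" and "open" are said of these compounds alone.

Compound 1 `CSc1cc(C)[nH]c(=O)c1CNC(=O)c1c(C)n([C@H](C)[C@H]2CC[C@H](N3CC(OC4CC4)C3)CC2)c2ncccc12` gives 0.057 nM in an assay on Sf9 cells for inhibition of histone-lysine N-methyltransferase EZH2 (Homo sapiens), read by scintillation counting, with stated times of 5 h and 20 h; on this read-out higher numbers stand for weaker inhibition and lower numbers for stronger inhibition. Compound 2 `CSc1cc(C)[nH]c(=O)c1CNC(=O)c1c(C)n([C@H](C)[C@H]2CC[C@H](N3CC(OC4CC4)C3)CC2)c2c(F)cccc12` gives 0.063 nM in this assay, and compound 3 `CSc1cc(C)[nH]c(=O)c1CNC(=O)c1c(C)n([C@H](C)[C@H]2CC[C@H](N3CC(OC4CC4)C3)CC2)c2ncc(Cl)cc12` gives 0.092 nM. Compound 3 carries the highest of the three numbers, yet both neighbours sit within the scatter of it, so no order among the three is established. Within the data shown here, the single one-place step measured so far is a 1.6-fold higher number from compound 1 to compound 3 (0.21 log units; within the scatter), the introduction of chloro in place of hydrogen on an aromatic carbon, and it stays within the scatter.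

Compound 4 `CSc1cc(C)[nH]c(=O)c1CNC(=O)c1c(C)n([C@H](C)[C@H]2CC[C@H](N3CC(OC4CC4)C3)CC2)c2ncc(F)cc12` is the next member. It differs from compound 3 by fluoro in place of chloro on an aromatic carbon. Among the measured compounds shown here, the one step that bears on it, from compound 1 to compound 3, shows that replacing hydrogen by chloro at this carbon left this assay essentially unchanged; fluoro is the remaining substituent for the same carbon, and no step beyond the scatter is expected from it. The step from compound 3 to compound 4 is estimated as a 1.3-fold lower number from compound 3 to compound 4 (0.12 log units; within the scatter). Compound 4 is therefore expected to give about 0.07 nM in this assay, with a range from 0.035 nM to 0.14 nM.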

Compound 4, half-maximal inhibitory concentration: 0.06 nM
The estimate for compound 4 lay 1.2-fold (0.07 log units) above the measured number; low and high end bracket the measured number.
By their numbers in this assay, from the lowest: compounds 1, 4, 2 and 3 (each within the scatter of the next).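

In this assay this aromatic carbon, two atoms from the ring nitrogen, now has a second halogen to set against hydrogen: fluoro in place of chloro gives a 1.5-fold lower number from compound 3 to compound 4 (0.19 log units; within the scatter) and fluoro in place of hydrogen gives a 1.1-fold higher number from compound 1 to compound 4 (0.02 log units; within the scatter) and so neither step moves the number beyond the scatter. Hydrogen, chloro and fluoro at this carbon (compound 1, compound 3 and compound 4) are therefore not told apart by this read-out, and the tolerance seen with chloro alone now extends to a second substituent. No measurement shown gives a reason for this result.

Going by these compounds, whether a methoxy group, an amine, a carboxylic acid or a longer alkyl chain at this carbon would keep the number within the scatter remains open. Also open, on these data alone, is whether hydrogen, chloro and fluoro stay indistinguishable in any read-out other than this assay.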